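Moving the methoxy group around the phenyl ring

The compounds below may be only part of what the source reports. "The series", "measured", "known", "first", "only" and "open" are said of these compounds alone.

Measured so far:
Compound 1, `COc1ccccc1N1CCN(C(=O)CCc2c(-c3ccccc3)[nH]c3ccc(C)cc23)CC1`: 6.1 nM
Compound 2, `COc1ccccc1N1CCN(C(=O)CCc2c(-c3ccccc3Br)[nH]c3ccc(C)cc23)CC1`: 89 nM
Compound 3, `COc1ccccc1-c1[nH]c2ccc(C)cc2c1CCC(=O)N1CCN(c2ccccc2OC)CC1`: 82 nM

All three share one core and differ only in the phenyl ring attached to it. In an assay on CHO cells for displacement of a labelled ligand from Substance-P receptor (Homo sapiens) (on this read-out lower numbers stand for stronger inhibition and higher numbers for weaker inhibition), compound 1 gives 6.1 nM, the lowest of the three numbers. Compound 3 stands second highest; it sits close to compound 2, the step of a 1.1-fold lower number from compound 2 to compound 3 (0.04 log units; within the scatter), and far from compound 1, the step of a 13-fold higher number from compound 1 to compound 3 (1.13 log units; beyond the scatter).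

Compound 4, `COc1cccc(-c2[nH]c3ccc(C)cc3c2CCC(=O)N2CCN(c3ccccc3OC)CC2)c1`, has not been measured. It differs from compound 3 in one place: 3-methoxyphenyl in place of 2-methoxyphenyl on an aromatic carbon. The methoxy group thus stays on the phenyl ring but moves to another carbon of it.

Among the compounds with values here, two measured steps bear on this. Adding a bromo group to the plain phenyl ring, a 15-fold higher number from compound 1 to compound 2 (1.16 log units; beyond the scatter), and adding a methoxy group in the same way, a 13-fold higher number from compound 1 to compound 3 (1.13 log units; beyond the scatter), both raised the number a lot, while exchanging one for the other, a 1.1-fold lower number from compound 2 to compound 3 (0.04 log units; within the scatter), changed little. Within the data shown here, no measured pair shows what moving a group to a different carbon of this ring does. Among the measured compounds shown here, because a methoxy group at the new carbon may not behave like the one in compound 3, a 13-fold higher number from compound 1 to compound 3 (1.13 log units; beyond the scatter), compound 4 is expected to fall somewhere between compound 1 and compound 3, with a step of a 2.7-fold lower number from compound 3 to compound 4 (0.44 log units; beyond the scatter). The estimate for compound 4 in this assay is 30 nM, with a range from 8 nM to 120 nM.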

Compound 4, half-maximal inhibitory concentration: 8 nM
Compound 4: middle estimate off by 3.8-fold (0.57 log units), on the high side; measured number inside the range.
By their numbers in this assay, from the lowest: compounds 1 and 4 (each within the scatter of the next); then compounds 3 and 2 (each within the scatter of the next).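

Moving the methoxy group from one carbon of the phenyl ring to another, with no atoms added or lost, has a large effect in this assay (a 10-fold lower number from compound 3 to compound 4 (1.01 log units; beyond the scatter)), so where the group sits matters, not only whether it is there. The earlier compounds shown here showed only that a bromo or a methoxy group in the 2-position of this ring raised the number, yet the 3-methoxyphenyl ring does not carry that cost: compared with the plain phenyl ring the change stays small (a 1.3-fold higher number from compound 1 to compound 4 (0.12 log units; within the scatter)), and compared with the 2-bromophenyl ring the number drops a long way (an 11-fold lower number from compound 2 to compound 4 (1.05 log units; beyond the scatter)). No measurement shown here explains why the two placements of the methoxy group differ so much.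

The compounds shown leave open whether this tolerance belongs to the methoxy group itself or to that carbon of the ring, which a 3-bromophenyl ring could help to settle. As far as these compounds go, how a hydroxyl group, an amine or a carboxylic acid would fare on the same carbon also remains unknown.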